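Methyl to Ethyl on a Benzimidazole-Linked Thiazolidinedione

A few compounds are considered here, and "the series" means these few. Any claim that something is new, unique, unknown or untested is made for them only; others in the source may bear on it.

Measured so far in a functional assay on A549 cells (Homo sapiens) for inhibition, read by MTT assay, with a stated time of 48 h; on this read-out higher numbers stand for weaker inhibition and lower numbers for stronger inhibition:
- compound 1, `Cn1c(/C=C2\SC(=O)N(CC(=O)Nc3nc(-c4ccccc4)cs3)C2=O)nc2ccccc21`: 11500 nM
- compound 2, `CCn1c(/C=C2\SC(=O)N(CC(=O)N3CCCC3)C2=O)nc2ccccc21`: 31200 nM
- compound 3, `CC(C)n1c(/C=C2\SC(=O)N(CC(=O)N3CCCC3)C2=O)nc2ccccc21`: for compound 3 the read-out is a limit, > 50000 nM, that is the limit of > 50000 nM in this assay, at which 1 of the 3 values shown sits.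

Compound 1 and compound 2 carry different amide ends, and the difference between the two cores is not broken down here. Within the core of compound 2, the change methyl in place of hydrogen on a saturated chain carbon bound to an aromatic nitrogen and a saturated chain carbon gave an at least 1.6-fold higher number from compound 2 to compound 3 (0.20 log units; that floor lies within the scatter). Compound 4, `CCn1c(/C=C2\SC(=O)N(CC(=O)Nc3nc(-c4ccccc4)cs3)C2=O)nc2ccccc21`, has not yet been measured; it differs from compound 1 by methyl in place of hydrogen on a saturated chain carbon bound to an aromatic nitrogen, the same kind of change, though here the carbon is bound to an aromatic nitrogen only and not also to a saturated chain carbon. Beside the earlier step, the step from compound 1 to compound 4 in this assay is expected to be a 1.6-fold higher number from compound 1 to compound 4 (0.19 log units; within the scatter), resting on the weakening seen in an at least 1.6-fold higher number from compound 2 to compound 3 (0.20 log units; that floor lies within the scatter) and on the value of compound 1, 11500 nM. Compound 4 is therefore estimated at 18000 nM, between 8000 nM and 45000 nM.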

Compound 4, half-maximal inhibitory concentration: > 50000 nM
Compound 4 ended at the assay's limit; the forecaster's own chance of this, stated with the estimate: 10%; middle value at least 2.7-fold (0.44 log units) away from the limit.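

In this assay compound 4 gives > 50000 nM, which is a limit of the assay and not a number. On the core of compound 1, going from methyl to ethyl gave an at least 4.3-fold higher number from compound 1 to compound 4 (0.63 log units; beyond the scatter), so this change clearly weakens inhibition on that core. Only minimum sizes are known for the step on each of the two cores, so the data do not show whether the change costs the same on both, or that its effect carries over unchanged from one core to the other: the same change on two cores in this assay, an at least 1.6-fold higher number (0.20 log units; that floor lies within the scatter) from compound 2 to compound 3 and an at least 4.3-fold higher number (0.63 log units; beyond the scatter) from compound 1 to compound 4; the limit leaves it open whether they differ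

The compounds shown leave open how far the loss goes with a longer chain such as propyl, or whether a chain ending in an amine or a carboxylic acid in place of the ethyl would bring inhibition back on the core of compound 1. They also leave open what a hydrogen in place of the methyl of compound 1 would give.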